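The compounds below may be only part of what the source reports. "The series", "measured", "known", "first", "only" and "open" are said of these compounds alone.

Measured compounds:
compound 1 `CCOC(=O)C(F)(F)C(O)CCc1ccccc1` — > 10000 nM
compound 2 `O=C(CCc1ccc(Cl)cc1)C(=O)N1CCCCC1` — > 10000 nM
compound 3 `COCCN(CCOC)C(=O)C(=O)CCc1ccc(Cl)cc1` — > 10000 nM

In an assay on HEK-293T cells for inhibition of phospholipase A and acyltransferase 2 (Homo sapiens), with stated times of 30 min and 20 min (a lower number here means a stronger inhibitor, a higher number a weaker inhibitor), compound 1 gives > 10000 nM, which is a limit of the assay and not a number. In this assay compound 2 gives > 10000 nM, again a limit. In this assay compound 3 gives > 10000 nM, also a limit. Compound 2 therefore stands at the limit of > 10000 nM in this assay, at which 3 of the 3 values shown sit, with no number of its own to rank it against the others.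

Compound 4 `O=C(CCc1ccc(Cl)cc1)C(=O)N1CCCC1` carries pyrrolidin-1-yl in place of piperidin-1-yl on a carbonyl carbon. Among the measured compounds shown here, no step between measured compounds is recorded, so the change has no measured precedent here. With compound 2 resting at a limit, the step from compound 2 to compound 4 is expected to be a step that the limit leaves unreadable from compound 2 to compound 4, that is, none beyond the scatter. Compound 4 is estimated at 15000 nM, between 5000 nM and 50000 nM.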

Compound 4, half-maximal inhibitory concentration: > 10000 nM
Compound 4 was reported as a limit (the forecaster's own chance of this, stated with the estimate: 85%); the middle value does not contradict the limit.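

Compound 2 and compound 4 both rest at a limit, so the step between them cannot be read: the limit of > 10000 nM in this assay, at which 4 of the 4 values shown sit.

The compounds shown leave open whether pyrrolidin-1-yl in place of piperidin-1-yl changes inhibition in this assay at all.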